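Methoxy for Methyl on Two Related Cores

This account rests on a few compounds, and the source may have more. Where it says the series, first, only, none or still open, it means among the compounds named here.

Compound 1, `Cc1cccc2c(NCc3ccco3)nc(NC(C)C)nc12`: in an ADME assay on J774.A1 cells (Mus musculus) for cytotoxicity, read by MTT assay, with a stated time of 72 h (a higher number here means that more compound is needed for the effect, a lower number that less compound is needed), compound 1 gives > 33000 nM, which is a limit of the assay and not a number.
Compound 2, `Cc1cccc2nc(NC(C)C)nc(NCc3ccco3)c12`: in this assay compound 2 gives 20000 nM.
Compound 3, `COc1cccc2c(NCc3ccco3)nc(NC(C)C)nc12`: in this assay compound 3 gives 30000 nM.

Compound 1 and compound 3 share a core and differ in one place, (methoxy in place of methyl on an aromatic carbon). In this assay this gave an at least 1.1-fold lower number from compound 1 to compound 3 (0.04 log units; that floor lies within the scatter), a step that starts from the limit of > 33000 nM in this assay, at which 1 of the 3 values shown sits, and therefore cannot be sized any more closely than that. Compound 2 is built from the same atoms as compound 1, joined differently; the difference between the two cores is not broken down here. The value of compound 2 stands closest to that of compound 3, and the gap between them lies within the usual scatter, so no order can be read from the pair.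

Compound 4, `COc1cccc2nc(NC(C)C)nc(NCc3ccco3)c12`, has not yet been measured in this assay. It differs from compound 2 by methoxy in place of methyl on an aromatic carbon, the same change that was made from compound 1 to compound 3, at a place described in the same words. Going by the values given here, the one measured step of this change was small and bounded only by a limit, so the expected step from compound 2 to compound 4 in this assay is a 1.1-fold lower number from compound 2 to compound 4 (0.05 log units; within the scatter), resting on an at least 1.1-fold lower number from compound 1 to compound 3 (0.04 log units; that floor lies within the scatter). For compound 4 in this assay the estimate is 18000 nM, with an expected range from 9000 nM to 36000 nM.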

Compound 4, half-maximal effective concentration: 18000 nM
Compound 4: middle estimate and measured number agree at the digits printed, and the stated range covers the measured number.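

In this assay, going by these compounds alone, methoxy in place of methyl on an aromatic carbon gave a 1.1-fold lower number from compound 2 to compound 4 (0.05 log units; within the scatter), so on this core the change produced no step that can be told from the usual scatter. Set beside the earlier step, this result shows that the same change has now been read on two cores, but it does not show that the change carries over with the same size: the same change on two cores in this assay, an at least 1.1-fold lower number (0.04 log units; that floor lies within the scatter) from compound 1 to compound 3 and a 1.1-fold lower number (0.05 log units; within the scatter) from compound 2 to compound 4; the limit leaves it open whether they differ. The earlier step is only a floor, since compound 1 stands at a limit of the assay and not at a number: the limit of > 33000 nM in this assay, at which 1 of the 4 values shown sits.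

The compounds shown hold only methyl and methoxy at this place, so what a chlorine atom, a nitrile or a longer chain such as ethoxy would give in this assay stays open. From the compounds shown here alone, it also stays open whether an amine or a carboxylic acid at this place would give a step beyond the scatter on either core, and whether any such step would carry over from one core to the other.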